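The compounds below may be only part of what the source reports. "The series", "measured", "known", "first", "only" and "open" are said of these compounds alone.

Measured so far in a functional assay on HepG2 cells (Homo sapiens) for antiproliferative activity, read by MTT assay, with a stated time of 48 h; a lower number here means a stronger inhibitor, a higher number a weaker inhibitor:
- Compound 1 (`CCn1cc(-c2nc3ccc([N+](=O)[O-])cc3o2)c(=O)c2cc(F)c(N3CCNC(C)C3)c(F)c21`) gives 2650 nM
- Compound 2 (`CCn1cc(-c2ccccc2)c(=O)c2cc(F)c(N3CCNCC3)cc21`) gives 30100 nM
- Compound 3 (`CCn1cc(-c2ccc(OC)cc2)c(=O)c2cc(F)c(N3CCNCC3)cc21`) gives 57900 nM

Compound 3, at 57900 nM here, lies within the scatter of compound 2, and both carry far higher numbers than compound 1. The next compound, compound 4 (`CCn1cc(-c2cccc(OC)c2)c(=O)c2cc(F)c(N3CCNCC3)cc21`), has the same atoms as compound 3, joined differently: 3-methoxyphenyl in place of 4-methoxyphenyl on an aromatic carbon. Among the measured compounds shown here, no measured pair shows a methoxy group moved around this ring. For the measured compounds named here, the nearest evidence is methoxy in place of hydrogen on an aromatic carbon, which gave a 1.9-fold higher number from compound 2 to compound 3 (0.28 log units; within the scatter) and is the only measured step that bears on the change. With so small a step for adding the group, moving it is expected to give no step beyond the scatter in this assay and no firm direction. Compound 4 is estimated at 45000 nM with an expected range of 20000 nM to 100000 nM around that figure. This estimate means an expected 1.3-fold lower number from compound 3 to compound 4 (0.11 log units; within the scatter) and nothing larger.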

Compound 4, half-maximal inhibitory concentration: 13000 nM
Estimate against measurement, compound 4: 3.5-fold (0.54 log units) above, and the stated range ends above it.
By their numbers in this assay, from the lowest: compound 1; then compound 4; then compounds 2 and 3 (each within the scatter of the next).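

In this assay, among the compounds shown here, the place of the methoxy group on this phenyl ring makes a difference that the earlier compounds could not show, with 3-methoxyphenyl in place of 4-methoxyphenyl giving a 4.5-fold lower number from compound 3 to compound 4 (0.65 log units; beyond the scatter) on an otherwise unchanged structure. Adding the group to the unsubstituted phenyl ring therefore has no single outcome: as 3-methoxyphenyl it gives a 2.3-fold lower number from compound 2 to compound 4 (0.36 log units; beyond the scatter) and moves beyond the scatter, while as 4-methoxyphenyl it gave a 1.9-fold higher number from compound 2 to compound 3 (0.28 log units; within the scatter) and stayed within it. Nothing available here accounts for this difference between the two placements.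

As far as these compounds go, whether a hydroxyl group, an ethoxy group or an amine in the place of the methoxy of compound 4 would give a similar number remains open. For the compounds shown here, also open is whether the difference between the two placements holds on another core, since only one pair of compounds shows it.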